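Swapping furan for phenyl on a nucleoside core

The source may report more compounds than this note shows. Statements on the series, on what has been measured and on what is new or still open speak of the compounds shown alone.

Measured so far in a functional assay on HepG2 cells (Homo sapiens) for antiproliferative activity, read by XTT assay, with a stated time of 72 h; a higher number here means a weaker inhibitor, a lower number a stronger inhibitor:
compound 1 `O=c1[nH]cnc2c1c(-c1ccoc1)cn2[C@@H]1O[C@H](CO)[C@@H](O)[C@H]1O` gives 12100 nM
compound 2 `Cc1ncnc2c1c(-c1cccs1)cn2[C@@H]1O[C@H](CO)[C@@H](O)[C@H]1O` gives only a limit of the assay, > 15000 nM
compound 3 `Nc1nc2c(c(-c3ccoc3)cn2[C@@H]2O[C@H](CO)[C@@H](O)[C@H]2O)c(=O)[nH]1` gives only a limit of the assay, > 20000 nM

Among the measured compounds shown here, compound 1 thus holds the only definite number in this assay; the other two compounds reached a limit. Compound 4 `O=c1[nH]cnc2c1c(-c1ccccc1)cn2[C@@H]1O[C@H](CO)[C@@H](O)[C@H]1O` differs from compound 1 by phenyl in place of furan-3-yl on an aromatic carbon. For the measured compounds named here, no measured step concerns such a ring swap. Going by the values given here, the single measured step, an at least 1.6-fold higher number from compound 1 to compound 3 (0.21 log units; that floor lies within the scatter), adds an amino group instead, and its floor lies within the scatter. Compound 2 differs from compound 1 in more than one place, so it only shows a limit. With nothing pointing in either direction, compound 4 is expected to give 12000 nM, in the range 5000 nM to 30000 nM. The expected step is a 1.0-fold lower number from compound 1 to compound 4 (0.00 log units; within the scatter), none beyond the scatter.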

Compound 4, half-maximal inhibitory concentration: > 20000 nM
Compound 4: a limit, no number; the forecaster's own chance of this, stated with the estimate: 30%; middle value at least 1.6-fold (0.22 log units) from the limit.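

In this assay, the swap of furan-3-yl for phenyl on this aromatic carbon gives an at least 1.6-fold higher number from compound 1 to compound 4 (0.21 log units; that floor lies within the scatter). Among the compounds shown here, this is the first measured change to the ring at this position, and it reveals no stronger inhibitor, though its floor does not establish a real loss either. Compound 4 ends at a limit of the assay, not a number, and shares that limit with compound 3: the limit of > 20000 nM in this assay, at which 2 of the 4 values shown sit.

From the compounds shown here alone, how far the true value of compound 4 lies beyond its limit stays open. Also open, going by these compounds, is what a group without a ring, such as an amine or a carboxylic acid, would give on this carbon.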